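The source may hold more compounds than are shown below. What is called first, only, known or untested is meant among the compounds shown, and "the series" means these compounds.

Series notes on an assay on brain for displacement of a labelled ligand from 5-hydroxytryptamine receptor 4 (Cavia porcellus), with a stated time of 30 min, in the presence of a further agent that is not named here; a lower number here means a stronger inhibitor, a higher number a weaker inhibitor:

compound 1, `COc1ccc(S(=O)(=O)NCCN2CCC(CCC(=O)c3cc(Cl)c(N)cc3OC)CC2)cc1Cl` — 22.5 nM
compound 2, `COc1cc(N)c(Cl)cc1C(=O)CCC1CCN(CCNS(=O)(=O)c2ccc(N)c(Br)c2)CC1` — 5.3 nM
compound 3, `COc1cc(N)c(Cl)cc1C(=O)CCC1CCN(CCNS(=O)(=O)c2ccc(NC(C)=O)cc2)CC1` — 7.7 nM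

Compound 3 holds the second highest of the three numbers in this assay. Its gap to compound 2 is within the scatter, whereas compound 1 lies clearly apart, as a 2.9-fold lower number from compound 1 to compound 3 (0.47 log units; beyond the scatter) shows.

Compound 4 is `COc1cc(N)c(Cl)cc1C(=O)CCC1CCN(CCNS(=O)(=O)c2cc(Br)c(N)c(Br)c2)CC1`. Relative to compound 3 the change is 4-amino-3,5-dibromophenyl in place of 4-acetamidophenyl on a sulfonyl sulfur. Among the compounds with values here, two measured steps bear on it. The first, a 1.5-fold higher number from compound 2 to compound 3 (0.16 log units; within the scatter), is within the scatter, so the exchange of 4-amino-3-bromophenyl for 4-acetamidophenyl moved nothing of note. The second, a 4.2-fold lower number from compound 1 to compound 2 (0.63 log units; beyond the scatter), puts the 4-amino-3-bromophenyl group among the lower numbers seen. Within the data shown here, compound 4 carries the 4-amino-3,5-dibromophenyl group; no measured pair shows what a second bromine does, so that part is uncharted. Because a 1.5-fold higher number from compound 2 to compound 3 (0.16 log units; within the scatter) is within the scatter, compound 4 is expected to give a step of a 1.4-fold lower number from compound 3 to compound 4 (0.15 log units; within the scatter), itself likely within the scatter. Compound 4 is estimated at 5.5 nM, with a range from 2.2 nM to 14 nM.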

Compound 4, inhibition constant: 8.7 nM
Compound 4: middle estimate off by 1.6-fold (0.20 log units), on the low side; the measured number falls inside the stated range.
By their numbers in this assay, from the lowest: compounds 2, 3 and 4 (each within the scatter of the next); then compound 1.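

In this assay, the series now has a direct reading of a second bromine on the phenyl group at the sulfonyl sulfur: bromo in place of hydrogen on an aromatic carbon gives a 1.6-fold higher number from compound 2 to compound 4 (0.22 log units; within the scatter), so the 4-amino-3-bromophenyl and 4-amino-3,5-dibromophenyl groups cannot be told apart here. The 4-amino-3,5-dibromophenyl group also cannot be told apart from 4-acetamidophenyl (a 1.1-fold higher number from compound 3 to compound 4 (0.05 log units; within the scatter)), yet it stays clear of the 3-chloro-4-methoxyphenyl group (a 2.6-fold lower number from compound 1 to compound 4 (0.41 log units; beyond the scatter)), leaving compound 1 alone among the four compounds. Nothing at hand accounts for these steps.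

As far as these compounds go, a plain 4-aminophenyl group and a 4-amino-3,5-dichlorophenyl group on the sulfonyl sulfur remain open. So does a 4-methoxyphenyl group, which would show whether the gap of compound 1 goes with its chloro or its methoxy substituent.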